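The compounds below may be only part of what the source reports. "The series", "measured", "known", "first", "only" and "open" are said of these compounds alone.

Measured in an ADME assay on L1210/0 cells (Mus musculus) for cytotoxicity, with a stated time of 48 h; on this read-out higher numbers stand for weaker inhibition and lower numbers for stronger inhibition:
compound 1 `N#CSc1cn([C@H]2C[C@H](O)[C@@H](CO)O2)c(=O)[nH]c1=O`: 78900 nM
compound 2 `N#Cc1cn([C@H]2C[C@H](O)[C@@H](CO)O2)c(=O)[nH]c1=O`: > 200000 nM (a limit of the assay, not a number)

Compound 2 has no number on this read-out, and that places it at the limit of > 200000 nM in this assay, at which 1 of the 2 values shown sits. Compound 3 `O=c1[nH]c(=O)n([C@H]2C[C@H](O)[C@@H](CO)O2)cc1C#CCO` differs from compound 2 by 3-hydroxyprop-1-yn-1-yl in place of cyano on an aromatic carbon, with 3-hydroxyprop-1-yn-1-yl in place of cyano on an aromatic carbon.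

Going by the values given here, only one measured step bears on this change: an at least 2.5-fold higher number from compound 1 to compound 2 (0.40 log units; beyond the scatter). It concerns the same place on the shared core, but its size is bounded, since it ends at a limit. Compound 1 at 78900 nM shows that the core can give a number in this assay when another group stands at this place. A step towards a lower number is therefore expected, of modest size like the measured one, though compound 3 may also remain at the limit.

The estimate for compound 3 is an expected 60000 nM, with an expected range of 10000 nM to 200000 nM. This corresponds to an expected at least 3.3-fold lower number from compound 2 to compound 3 (0.52 log units; beyond the scatter).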

Compound 3, half-maximal inhibitory concentration: > 200000 nM
Compound 3 gave a limit, no number; the forecaster's own chance of this, stated with the estimate: 30%; middle value at least 3.3-fold (0.52 log units) from the limit.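

In this assay, compound 3 gives a limit and not a number, as compound 2 does, which leaves compound 1 as the only one of the three with a number: the limit of > 200000 nM in this assay, at which 2 of the 3 values shown sit.

Swapping the cyanosulfanyl group for 3-hydroxyprop-1-yn-1-yl gives an at least 2.5-fold higher number from compound 1 to compound 3 (0.40 log units; beyond the scatter). Two different groups at this place, cyano and 3-hydroxyprop-1-yn-1-yl, thus both lie on the same side of compound 1, so the number of compound 1 no longer stands against just one replacement. The step between compound 2 and compound 3 cannot be read, as both of its ends are limits, and the two groups cannot be ranked against each other.

From the compounds shown here alone, whether the number of compound 1 depends on the sulfur atom of cyanosulfanyl or on the group as a whole remains open, as does how far compound 2 and compound 3 lie from each other. A group such as methylsulfanyl or an amine at this place would bear on the first of these questions.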